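Cytotoxicity notes on the bicyclic nucleoside series: acyl urea

The compounds below may be only part of what the source reports. "The series", "measured", "known", "first", "only" and "open" are said of these compounds alone.

Measured compounds and values:
compound 1 `CCNC(=O)NC1=CS(=O)(=O)O[C@@]12[C@@H](CO[Si](C)(C)C(C)(C)C)O[C@@H](n1cc(C)c(=O)n(C)c1=O)[C@@H]2O[Si](C)(C)C(C)(C)C` — >= 3200 nM
compound 2 `Cc1cn([C@@H]2O[C@H](CO[Si](C)(C)C(C)(C)C)[C@@]3(OS(=O)(=O)C=C3NC(=O)c3ccccc3)[C@H]2O[Si](C)(C)C(C)(C)C)c(=O)n(C)c1=O` — >= 3200 nM
compound 3 `COC(=O)CC(=O)NC1=CS(=O)(=O)O[C@@]12[C@@H](CO[Si](C)(C)C(C)(C)C)O[C@@H](n1cc(C)c(=O)n(C)c1=O)[C@@H]2O[Si](C)(C)C(C)(C)C` — 400000 nM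

In a functional assay on HEL cells (Homo sapiens) for cytotoxicity, read by microscopy (on this read-out higher numbers stand for lower toxicity in this test and lower numbers for higher toxicity in this test), compound 1 gives >= 3200 nM, which is a limit of the assay and not a number. Compound 2 likewise gives only a limit, >= 3200 nM. Within the data shown here, compound 3 is the one compound of the three with a measured number, 400000 nM. Two of the three values therefore sit at a limit (the limit of >= 3200 nM in this assay, at which 2 of the 3 values shown sit), and none of the steps among the measured compounds can be read: a step that the two limits leave unreadable from compound 1 to compound 2, a step that the limit leaves unreadable from compound 1 to compound 3 and a step that the limit leaves unreadable from compound 2 to compound 3.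

The unmeasured compound 4 `Cc1cn([C@@H]2O[C@H](CO[Si](C)(C)C(C)(C)C)[C@@]3(OS(=O)(=O)C=C3NC(=O)NC(=O)c3ccccc3)[C@H]2O[Si](C)(C)C(C)(C)C)c(=O)n(C)c1=O` differs from compound 1 as follows: benzoyl in place of ethyl on an amide-type nitrogen. The nearest measured precedent is compound 2, where phenyl stands on the carbonyl carbon, and compound 2 sits at the limit; compound 3 shows that a measured number far from the limit is also possible in this series.

The step from compound 1 to compound 4 is expected to be a step that the limit leaves unreadable from compound 1 to compound 4, with the caveat that compound 1 is itself only a limit. For compound 4 the estimate in this assay is 20000 nM, with a range from 3200 nM to 400000 nM, and a limit rather than a number is considered the more likely outcome.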

Compound 4, minimum cytotoxic concentration: >= 80000 nM
Compound 4 ended at the assay's limit; the forecaster's own chance of this, stated with the estimate: 60%; middle value at least 4.0-fold (0.60 log units) away from the limit.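

Compound 4 returns only a limit and not a number, and the steps linking it to compound 1, compound 2 and compound 3 therefore cannot be read. The compounds shown leave open how much benzoyl in place of ethyl on the amide-type nitrogen changes cytotoxicity, and whether compound 1, compound 2 and compound 4 differ from compound 3 at all.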